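This account rests on a few compounds, and the source may have more. Where it says the series, first, only, none or still open, it means among the compounds named here.

Going by the values given here, compound 1 `Cc1cc(C)cc(NC(=O)CN2CCC(c3cccc[n+]3[O-])CC2)c1` gives the lower of the two numbers measured so far in a functional assay on HEK293 cells for agonist activity at D(4) dopamine receptor (Homo sapiens), read by FLIPR; on this read-out lower numbers stand for an effect already at smaller amounts and higher numbers for an effect only at larger amounts of compound: compound 1 gives 52 nM, while compound 2 `O=C(CN1CCC(c2ccccn2)CC1)Nc1c(Cl)cc(Cl)cc1Cl` gives 145 nM, a gap beyond the usual scatter. Compound 3 `O=C(CN1CCC(c2cccc[n+]2[O-])CC1)Nc1cc(Cl)cc(Cl)c1` has not yet been measured. It keeps the shared core of compound 1 and differs from it by 3,5-dichlorophenyl in place of 3,5-dimethylphenyl on an amide-type nitrogen. Among the compounds with values here, no measured pair differs in exactly this way, and the size of the step is open; a change within the scatter, or a modest rise in the number, seems most plausible. In this assay the expected step is a 1.5-fold higher number from compound 1 to compound 3 (0.19 log units; within the scatter). Compound 3 is estimated at 80 nM, with a likely range from 30 nM to 250 nM.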

Compound 3, half-maximal effective concentration: 160 nM
The estimate for compound 3 lay 2.0-fold (0.30 log units) below the measured number, and the stated range covers the measured number.
By their numbers in this assay, from the lowest: compound 1; then compounds 2 and 3 (each within the scatter of the next).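

In this assay, with the shared core kept, placing 3,5-dichlorophenyl instead of 3,5-dimethylphenyl on the amide-type nitrogen gives a 3.1-fold higher number from compound 1 to compound 3 (0.49 log units; beyond the scatter). Going by these compounds alone, this is the first single-place comparison here, and it shows that the number responds to this swap, even though the two groups have the same count of heavy atoms. Nothing here shows why the number moves.

As far as these compounds go, it remains open where a plain phenyl or a 3,5-dimethoxyphenyl group would fall at this position. From the compounds shown here alone, it is also open whether the same swap would give a similar step on another core.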